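Enlarging the group on the aromatic nitrogen of a purine core

This account rests on a few compounds, and the source may have more. Where it says the series, first, only, none or still open, it means among the compounds named here.

The series is read in a functional assay on AGS cells (Homo sapiens) for antiproliferative activity, read by MTT assay, with a stated time of 48 h; on this read-out lower numbers stand for stronger inhibition of growth and higher numbers for weaker inhibition of growth. Compound 1 `COc1ccc(N(C)c2nc(Cl)nc3[nH]cnc23)cc1` gives 30000 nM there. Among the compounds with values here, compound 2 `COc1ccc(N(C)c2nc(Cl)nc3c2ncn3C)cc1` gives 260 nM, and the single step connecting them, a 120-fold lower number from compound 1 to compound 2 (2.06 log units; beyond the scatter), is the only change measured so far. On these two numbers compound 2 stands lowest, its nearest neighbour being compound 1.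

Compound 3 `COc1ccc(N(C)c2nc(Cl)nc3c2ncn3Cc2ccc(OC)c(OC)c2)cc1` is not yet measured. It differs from compound 2 by 3,4-dimethoxyphenyl in place of hydrogen on a saturated chain carbon bound to an aromatic nitrogen. Within the data shown here, the one measured step touches the same aromatic nitrogen but concerns a hydrogen giving way to methyl, not growth of what sits on that methyl carbon, so it bears on compound 3 only loosely. Compound 3 is therefore expected to stay close to compound 2, with a step of a 1.0-fold lower number from compound 2 to compound 3 (0.02 log units; within the scatter) in this assay. Compound 3 is estimated at 250 nM, within 60 nM to 1000 nM.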

Compound 3, concentration for 50% growth inhibition: 56000 nM
Beside the measured number, compound 3's estimate is 220-fold (2.35 log units) below it; the whole stated range lies below it.
By their numbers in this assay, from the lowest: compound 2; then compounds 1 and 3 (each within the scatter of the next).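

At this aromatic nitrogen, growth of the group does not continue the earlier gain: in this assay, 3,4-dimethoxyphenyl in place of hydrogen on the saturated chain carbon bound to the nitrogen gives a 220-fold higher number from compound 2 to compound 3 (2.33 log units; beyond the scatter). The earlier step, methyl in place of hydrogen on the same nitrogen, gave a 120-fold lower number from compound 1 to compound 2 (2.06 log units; beyond the scatter), so these two steps run in opposite directions and the outcome at this position depends on which group enters. The data shown offer no measurement that accounts for this reversal.

The compounds shown leave open whether an ethyl group or a longer chain on this nitrogen would stay near compound 2 or move towards compound 3. They also do not separate the effect of the aromatic ring from that of its two methoxy groups, which a plain phenyl group at the same place would address.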